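The source may report more compounds than this note shows. Statements on the series, on what has been measured and on what is new or still open speak of the compounds shown alone.

Three compounds have been measured in an assay on LtK cells with ATP-sensitive inward rectifier potassium channel 11 (Homo sapiens) as the target; on this read-out lower numbers stand for an effect already at smaller amounts and higher numbers for an effect only at larger amounts of compound:

Compound 1, `COCC(=O)Nc1c(C(O)(C(F)(F)F)C(F)(F)F)ccc2ccccc12`: 213 nM
Compound 2, `O=C(Nc1c(C(O)(C(F)(F)F)C(F)(F)F)ccc2ccccc12)c1cccc([N+](=O)[O-])c1`: 117 nM
Compound 3, `COc1cccc(C(=O)Nc2c(C(O)(C(F)(F)F)C(F)(F)F)ccc3ccccc23)c1`: 185 nM

All three share the same core and differ only in the group attached to the carbonyl carbon of the amide. The three numbers lie close together: the step of a 1.2-fold lower number from compound 1 to compound 3 (0.06 log units; within the scatter) and the step of a 1.6-fold higher number from compound 2 to compound 3 (0.20 log units; within the scatter) are both within the scatter, so compound 3 cannot be set apart from either of the other two on these numbers.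

Compound 4, `O=C(Nc1c(C(O)(C(F)(F)F)C(F)(F)F)ccc2ccccc12)c1ccc(F)cc1`, has not yet been measured. It differs from compound 3 in one place: 4-fluorophenyl in place of 3-methoxyphenyl on a carbonyl carbon.

The measured steps that bear on this change are those in which the group on the carbonyl carbon was exchanged: a 1.8-fold lower number from compound 1 to compound 2 (0.26 log units; within the scatter), a 1.2-fold lower number from compound 1 to compound 3 (0.06 log units; within the scatter) and a 1.6-fold higher number from compound 2 to compound 3 (0.20 log units; within the scatter). None of these went beyond the scatter, whether the group exchanged was a short chain or a substituted six-membered aromatic ring. Going by the values given here, nothing measured so far points to a move in either direction for a further exchange of this kind.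

For compound 4 the expected number in this assay is therefore 175 nM, with a range from 80 nM to 400 nM. The step from compound 3 that this estimate implies is a 1.1-fold lower number from compound 3 to compound 4 (0.02 log units; within the scatter), expected to stay within the scatter.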

Compound 4, half-maximal effective concentration: 70 nM
Estimate against measurement, compound 4: 2.5-fold (0.40 log units) above, and the stated range ends above it.
By their numbers in this assay, from the lowest: compounds 4, 2, 3 and 1 (each within the scatter of the next, the first and the last beyond it).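

Until now, no exchange of the group on the carbonyl carbon had gone beyond the scatter in this assay, so the position could have seemed indifferent to what sits there. 4-Fluorophenyl changes that picture, with a 2.6-fold lower number from compound 3 to compound 4 (0.42 log units; beyond the scatter) and a 3.0-fold lower number from compound 1 to compound 4 (0.48 log units; beyond the scatter) as modest steps that show the number can move with this group, yet a 1.7-fold lower number from compound 2 to compound 4 (0.22 log units; within the scatter) keeps compound 4 and compound 2 apart by no more than repeated measurements would. Nothing measured here explains the step from 3-methoxyphenyl to 4-fluorophenyl.

That step swaps the methoxy for a fluorine and also changes the ring number at which the substituent is named, so the compounds shown cannot say which of the two matters; a pair carrying 3-fluorophenyl and 4-methoxyphenyl would separate them. Also open, going by these compounds, is how this position would respond to a longer chain on the carbonyl carbon, or to a phenyl ring bearing an amine or a carboxylic acid.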